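A few compounds are considered here, and "the series" means these few. Any claim that something is new, unique, unknown or untested is made for them only; others in the source may bear on it.

The measured compounds:
compound 1 `CC(C)c1[nH]cnc1/C=c1\[nH]c(=O)/c(=C/c2cccc(Oc3ccc(F)cc3)c2)[nH]c1=O` — 8.8 nM
compound 2 `O=C(c1ccc(F)cc1)c1cccc(/C=c2\[nH]c(=O)/c(=C/c3nc[nH]c3C3CC3)[nH]c2=O)c1` — 2.8 nM
compound 3 `O=c1[nH]/c(=C\c2cccc(Oc3ccc(F)cc3)c2)c(=O)[nH]/c1=C\c1cccnc1` — > 1000 nM

Of the compounds shown here, three sharing the core of compound 1 have been tested in a functional assay on NCI-H460 cells (Homo sapiens) for cytotoxicity, read by MTT assay, with a stated time of 72 h; a higher number here means a weaker inhibitor, a lower number a stronger inhibitor. Compound 1 gives 8.8 nM, and compound 2 gives 2.8 nM. For compound 3 the this assay returns only a limit, > 1000 nM, so no number is known for compound 3. That limit is the limit of > 1000 nM in this assay, at which 1 of the 3 values shown sits, and compound 3 therefore stands at the weak end of the three values shown. Within the data shown here, the one measured step at this position is an at least 110-fold higher number from compound 1 to compound 3 (2.05 log units; beyond the scatter).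

Compound 4 `O=c1[nH]/c(=C\c2ccc(CO)o2)c(=O)[nH]/c1=C\c1cccc(Oc2ccc(F)cc2)c1` differs from compound 3 in one place: 5-(hydroxymethyl)furan-2-yl in place of pyridin-3-yl on a double-bonded chain carbon bound to an aromatic carbon

Among the measured compounds shown here, only the step from compound 1 to compound 3 bears on this position, and it was large, with the pyridin-3-yl giving the weakest result of the set while compound 1 and compound 2 both carry imidazolyl groups there. For the measured compounds named here, no measured pair shows how a 5-(hydroxymethyl)furan-2-yl compares with either. The step that the limit leaves unreadable from compound 3 to compound 4 is therefore expected to be small and uncertain in direction, with compound 4 likely to remain near the weak end. Compound 4 is estimated to give about 1500 nM in this assay, within a range from 200 nM to 10000 nM.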

Compound 4, half-maximal inhibitory concentration: 41.5 nM
Beside the measured number, compound 4's estimate is 36-fold (1.56 log units) above it; the whole stated range lies above it.
By their numbers in this assay, from the lowest: compound 2; then compound 1; then compound 4. At a limit, above all of these: compound 3.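

In this assay compound 3 stands only at a limit, so the size of any step from it is a bound rather than a number: the limit of > 1000 nM in this assay, at which 1 of the 4 values shown sits.

With 5-(hydroxymethyl)furan-2-yl in place of pyridin-3-yl, the result is an at least 24-fold lower number from compound 3 to compound 4 (1.38 log units; beyond the scatter), which shows that this position on the double-bonded chain carbon bound to an aromatic carbon can hold a ring other than an imidazole and still give a nanomolar value. Measured against the 5-isopropyl-1H-imidazol-4-yl, the new group gives a 4.7-fold higher number from compound 1 to compound 4 (0.67 log units; beyond the scatter), a modest loss next to the earlier at least 110-fold higher number from compound 1 to compound 3 (2.05 log units; beyond the scatter), so the large step seen before belongs to the pyridin-3-yl and not to every replacement of the imidazole.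

The compounds shown do not separate the contribution of the furan ring from that of its hydroxymethyl group. A plain furan-2-yl, or a furan carrying an aminomethyl group or a carboxylic acid in place of the hydroxymethyl, would be needed to settle which part of the group accounts for the difference from compound 3.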